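This account rests on a few compounds, and the source may have more. Where it says the series, first, only, none or still open, it means among the compounds named here.

The measured compounds are:

compound 1 `COc1ccc(-c2nc(CNC(=O)c3cccnc3)sc2-c2ccc(OC)cc2)cc1` — 8.2 uM
compound 2 `COc1ccc(-c2nc(CNC(=O)CSc3ccccc3)sc2-c2ccc(OC)cc2)cc1` — 4.2 uM
compound 3 `COc1ccc(-c2nc(C(=O)N3CCN(C(=O)NC(C)C)CC3)sc2-c2ccc(OC)cc2)cc1` — 15 uM

In a functional assay (aorta) with Rattus norvegicus as the target (on this read-out lower numbers stand for an effect already at smaller amounts and higher numbers for an effect only at larger amounts of compound), compound 2 gives 4.2 uM, the lowest of the three numbers. Compound 1 gives 8.2 uM, and the step of a 2.0-fold lower number from compound 1 to compound 2 (0.29 log units; within the scatter) is within the scatter, so the two cannot be ranked against each other. Compound 3 gives 15 uM, and its gap to compound 2 lies beyond the scatter.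

Compound 4 `COc1ccc(-c2nc(CCC(=O)O)sc2-c2ccc(OC)cc2)cc1` has not yet been tested in this assay. Against compound 2 the change is carboxymethyl in place of (((phenylsulfanyl)methyl)carbonyl)amino on a saturated chain carbon bound to an aromatic carbon. Within the data shown here, only one measured step exists, the one from compound 1 to compound 2, which replaced one group on the carbonyl carbon by another and stayed within the scatter; no measured step removes the whole amide or introduces an acid, and compound 3 differs from compound 2 in more than one place, so it yields no single step. The expectation therefore rests on little: a step of a 4.8-fold higher number from compound 2 to compound 4 (0.68 log units; beyond the scatter) is estimated, most likely towards a higher number, but with wide uncertainty. For compound 4 the estimate in this assay is 20 uM, expected to fall between 6 uM and 70 uM.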

Compound 4, concentration for half-maximal effect: > 100 uM
Compound 4: only a limit was reported; the forecaster's own chance of this, stated with the estimate: 25%; middle value at least 5.0-fold (0.69 log units) from the limit.
By their numbers in this assay, from the lowest: compounds 2, 1 and 3 (each within the scatter of the next, the first and the last beyond it). At a limit, above all of these: compound 4.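

In this assay compound 4 stands at a limit and not at a number: the limit of > 100 uM in this assay, at which 1 of the 4 values shown sits.

Carboxymethyl in place of (((phenylsulfanyl)methyl)carbonyl)amino, on a saturated chain carbon bound to an aromatic carbon, gives an at least 23-fold higher number from compound 2 to compound 4 (1.37 log units; beyond the scatter), and carboxymethyl in place of ((pyridin-3-yl)carbonyl)amino gives an at least 12-fold higher number from compound 1 to compound 4 (1.08 log units; beyond the scatter). Among these compounds, exchanging the group on the carbonyl carbon had given only a 2.0-fold lower number from compound 1 to compound 2 (0.29 log units; within the scatter), so the earlier compounds left it possible that the read-out was indifferent to changes here, and compound 4 shows that it is not: both large steps point the same way once the whole amide-bearing group leaves.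

The compounds shown leave open whether these steps belong to the carboxylic acid that enters or to the amide and its aromatic ring that leave, since both changes happen together in compound 4. A methyl ester or a primary amide in place of the carboxylic acid, or a longer chain carrying the acid, would be needed to tell these two readings apart.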